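The source may report more compounds than this note shows. Statements on the series, on what has been measured and on what is new or still open speak of the compounds shown alone.

Of the compounds shown here, two have numbers so far. Compound 1 `O=S(=O)(NCCNCc1ccc(-c2ccccc2)cc1)c1cc(C(F)(F)F)cc(C(F)(F)F)c1` gives 2400 nM in a functional assay on Capan-2 cells (Homo sapiens) for inhibition, read by MTT assay, with a stated time of 72 h (a lower number here means a stronger inhibitor of growth, a higher number a weaker inhibitor of growth), and compound 2 `COc1ccc(CNCCCNS(=O)(=O)c2cc(C(F)(F)F)cc(C(F)(F)F)c2)cc1OC` gives 15000 nM, the highest of the two numbers and well outside the usual scatter of compound 1. Compound 3 `O=S(=O)(NCCCNCc1ccc(Br)cc1)c1cc(C(F)(F)F)cc(C(F)(F)F)c1` has not been measured. It differs from compound 2 in one place: 4-bromophenyl in place of 3,4-dimethoxyphenyl on a saturated chain carbon bound to an amine nitrogen. Among the measured compounds shown here, no single-change step between measured compounds is available to set the size of this change. Given that compound 1 sits at 2400 nM, a modest improvement is expected, an estimated step of a 2.1-fold lower number from compound 2 to compound 3 (0.33 log units; beyond the scatter). Compound 3 is therefore estimated at 7000 nM, with a likely range from 2500 nM to 20000 nM.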

Compound 3, concentration for 50% growth inhibition: 2000 nM
Compound 3: middle estimate off by 3.5-fold (0.54 log units), on the high side, and the stated range ends above it.
By their numbers in this assay, from the lowest: compounds 3 and 1 (each within the scatter of the next); then compound 2.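

Among the compounds shown here, this is the first single-change step: with the rest of the molecule held constant, 4-bromophenyl in place of 3,4-dimethoxyphenyl in this assay gives a 7.5-fold lower number from compound 2 to compound 3 (0.88 log units; beyond the scatter). The group on this saturated chain carbon bound to an amine nitrogen therefore affects growth inhibition in these cells. Nothing available explains the step.

From the compounds shown here alone, it remains open whether the bromine or the loss of both methoxy groups matters, which 4-methoxyphenyl or 4-chlorophenyl at this place could separate. Going by these compounds, the effect of a longer chain with 4-bromophenyl kept also remains open.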